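Acrylamide to bromocrotonamide on a trimethoxyphenyl benzylamide

The source may hold more compounds than are shown below. What is called first, only, known or untested is meant among the compounds shown, and "the series" means these compounds.

Compound 1: `C/C=C/C(=O)N(Cc1ccc(OC)c(OC)c1)c1cc(OC)c(OC)c(OC)c1` — 32800 nM
Compound 2: `C=C(C)C(=O)N(Cc1ccc(OC)c(O)c1)c1cc(OC)c(OC)c(OC)c1` — 200 nM
Compound 3: `COc1ccc(CNc2cc(OC)c(OC)c(OC)c2)cc1F` — 32200 nM

Of the compounds shown here, three have been measured in a functional assay on HCT-116 cells (Homo sapiens) for inhibition, read by MTT assay, with a stated time of 48 h; a higher number here means a weaker inhibitor, a lower number a stronger inhibitor. Compound 1 gives 32800 nM, compound 3 gives 32200 nM, and compound 2 gives 200 nM. Compound 2 therefore stands with the lowest number of the three, and both of the others lie far beyond the scatter from it, each at the same distance.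

The unmeasured compound 4 `COc1ccc(CN(C(=O)/C=C/CBr)c2cc(OC)c(OC)c(OC)c2)cc1O` is derived from compound 2 by one change: 3-bromoprop-1-en-1-yl in place of 1-methylethenyl on a carbonyl carbon. The rest of the molecule, including the shared core and the benzyl part, is unchanged.

Among the compounds with values here, no measured pair with this change exists to set the size of the step, so the expectation rests on compound 2 alone, whose value 200 nM is the anchor. The step from compound 2 to compound 4 is expected to be small, most likely none beyond the scatter, with a slight lean toward a lower number, a 1.3-fold lower number from compound 2 to compound 4 (0.12 log units; within the scatter). Compound 4 is thus estimated at 150 nM, within a range from 40 nM to 600 nM.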

Compound 4, half-maximal inhibitory concentration: 59 nM
Estimate against measurement, compound 4: 2.5-fold (0.41 log units) above; low and high end bracket the measured number.
By their numbers in this assay, from the lowest: compound 4; then compound 2; then compounds 3 and 1 (each within the scatter of the next).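

In this assay, within the data shown here, the change from 1-methylethenyl to 3-bromoprop-1-en-1-yl on a carbonyl carbon gives a 3.4-fold lower number from compound 2 to compound 4 (0.53 log units; beyond the scatter), the first step in this set between compounds that differ in one place. It shows that this place on the amide-type nitrogen's carbonyl accepts a bromine-bearing chain with a modest gain, and that compound 2 was not the limit of what this position can give in this assay. No supporting measurement bears on why the number falls.

The compounds shown leave open whether the bromine itself matters, which a 3-chloroprop-1-en-1-yl group or a chain ending in a dimethylamino group at the same place would test. Among these compounds, whether the step carries over to a different benzyl part, such as the one in compound 1, also remains open.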